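A second 4-nitrobenzyl group on the shared core

This account rests on a few compounds, and the source may have more. Where it says the series, first, only, none or still open, it means among the compounds named here.

In a functional assay (Homo sapiens) for antiproliferative activity (a higher number here means a weaker inhibitor, a lower number a stronger inhibitor), compound 1 `COC1=C(OCc2ccc([N+](=O)[O-])cc2)/C(=C\Cn2cnc3c(Cl)ncnc32)OC1=O` gives 3980 nM as its result. Compound 2 `COC1=C(OCc2ccc([N+](=O)[O-])cc2)C(=O)O/C1=C/Cn1cnc2c(Cl)ncnc21` gives 5040 nM and so stands within the usual scatter of compound 1, which means the two numbers cannot be told apart. Both compounds carry the same groups, arranged differently on the shared core.

Compound 3 `O=C1O/C(=C/Cn2cnc3c(Cl)ncnc32)C(OCc2ccc([N+](=O)[O-])cc2)=C1OCc1ccc([N+](=O)[O-])cc1` is reached from compound 2 by one structural change. That change is 4-nitrophenyl in place of hydrogen on a saturated chain carbon bound to an oxygen on an unsaturated carbon and, in words, it puts 4-nitrophenyl in place of hydrogen on a saturated chain carbon bound to an oxygen on an unsaturated carbon. The methoxy thus becomes a (4-nitrobenzyl)oxy.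

Among the compounds with values here, no measured pair of compounds shows what this change does, so any expectation here is loose. A small move toward a stronger inhibitor is expected, and the estimated step is a 1.7-fold lower number from compound 2 to compound 3 (0.23 log units; within the scatter) and would stay close to the scatter. For compound 3 the estimated value is 3000 nM with an expected range from 1000 nM to 9000 nM as a working guess.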

Compound 3, half-maximal inhibitory concentration: > 120000 nM
Compound 3: a limit, no number; the forecaster's own chance of this, stated with the estimate: 5%; at least 40-fold (1.60 log units) between middle value and limit.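

In this assay, replacing a methoxy with a second (4-nitrobenzyl)oxy on the shared core is far from a small adjustment: it gives an at least 23-fold higher number from compound 2 to compound 3 (1.37 log units; beyond the scatter), and read against the other arrangement of the same groups, it gives an at least 30-fold higher number from compound 1 to compound 3 (1.47 log units; beyond the scatter). Both steps rest on a limit of the assay and not on a number: the limit of > 120000 nM in this assay, at which 1 of the 3 values shown sits. Compounds 1 and 2 could not be told apart, so they showed no effect of rearranging their groups, whereas compound 3 shows that the result depends strongly on what this saturated chain carbon bound to an oxygen on an unsaturated carbon carries, with hydrogen there in compound 2 and 4-nitrophenyl in compound 3.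

The compounds shown cannot say whether the loss of activity belongs to the 4-nitrophenyl as a whole or to its nitro group alone, and an ethoxy or a plain benzyloxy at this place would be needed to begin separating those readings. They also give no reason for the loss, and they leave open whether any group larger than methoxy can be carried here with activity kept.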